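Cytotoxicity limits and the step to compound 3

The source may hold more compounds than are shown below. What is called first, only, known or untested is meant among the compounds shown, and "the series" means these compounds.

Measured so far in an ADME assay on HepG2 cells (Homo sapiens) for cytotoxicity, in the presence of a further agent that is not named here; on this read-out lower numbers stand for stronger inhibition and higher numbers for weaker inhibition
- Compound 1 `Cn1c(Cc2ccccc2C(F)(F)F)nc(C(=O)NCc2cccnc2)c(O)c1=O` gives > 100000 nM as a limit
- Compound 2 `Cn1c(Cc2ccccc2C(F)(F)F)nc(C(=O)Nc2ccccc2)c(O)c1=O` gives > 100000 nM as a limit

Compound 2 stands at > 100000 nM in this assay and this is a limit rather than a number. The next compound, compound 3 `CC(NC(=O)c1nc(Cc2ccccc2C(F)(F)F)n(C)c(=O)c1O)c1ccccc1`, carries 1-phenylethyl in place of phenyl on the amide-type nitrogen (1-phenylethyl in place of phenyl on an amide-type nitrogen). Among the measured compounds shown here, the only measured step on that nitrogen is a step that the two limits leave unreadable from compound 1 to compound 2 with phenyl in place of (pyridin-3-yl)methyl, so it offers no size to carry over. For the measured compounds named here, the series so far shows the limit of > 100000 nM in this assay, at which 2 of the 2 values shown sit, and no actual number yet. Resting on compound 2 and the limit of > 100000 nM in this assay, at which 2 of the 2 values shown sit, no step beyond the usual scatter is expected in this assay for this change, and no direction can be given. The expected size is a number no higher from compound 2 to compound 3 (the limit leaves the size open) and this is only an estimate. For compound 3 the estimated value is 100000 nM with an expected range from 50000 nM to 200000 nM and a report of only a limit is the likeliest outcome.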

Compound 3, half-maximal inhibitory concentration: > 100000 nM
Compound 3 was reported as a limit (the forecaster's own chance of this, stated with the estimate: 80%); the middle value lies on the limit itself.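

In this assay compound 3 gives > 100000 nM, which is a limit and not a number. No step can be read among compound 1, compound 2 and compound 3, as all three stop at the same limit: the limit of > 100000 nM in this assay, at which 3 of the 3 values shown sit. The compounds shown leave open what actual value any of them has, and whether changing the group on the amide-type nitrogen shifts it.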